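The compounds below may be only part of what the source reports. "The series", "measured", "known", "first", "only" and "open" are said of these compounds alone.

In a functional assay on HCT-116 cells (Homo sapiens) for cytotoxicity, read by MTT assay, with a stated time of 72 h (a lower number here means a stronger inhibitor, a higher number a weaker inhibitor), compound 1 `O=C(/C=C/c1ccc(NC(=O)Nc2ccccc2)cc1)NO` gives 6490 nM, compound 2 `O=C(/C=C/c1ccc(NC(=O)Nc2ccc([N+](=O)[O-])cc2)cc1)NO` gives 12600 nM and compound 3 `O=C(CCc1ccc(NC(=O)Nc2ccccc2)cc1)NO` gives 16200 nM. Compound 3 thus lies within the scatter of compound 2 but apart from compound 1. Putting 2-(hydroxycarbamoyl)ethyl in place of 2-(hydroxycarbamoyl)ethenyl gave a 2.5-fold higher number from compound 1 to compound 3 (0.40 log units; beyond the scatter), a modest step beyond the scatter.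

Compound 4 `O=C(CCc1ccc(NC(=O)Nc2ccc([N+](=O)[O-])cc2)cc1)NO` is compound 3 with nitro in place of hydrogen on an aromatic carbon. The same exchange has been measured only once, in the pair with the 2-(hydroxycarbamoyl)ethenyl chain, where it gave a 1.9-fold higher number from compound 1 to compound 2 (0.29 log units; within the scatter), a step within the scatter. That single pair is the direct guide, and the data do not show whether it carries over to the 2-(hydroxycarbamoyl)ethyl chain. The step of a 2.5-fold higher number from compound 1 to compound 3 (0.40 log units; beyond the scatter) bears only on the chain, and it says nothing about the nitro exchange itself.

A small step in the same direction is therefore expected in this assay, with no clear move beyond the scatter. The expected step is a 1.5-fold higher number from compound 3 to compound 4 (0.17 log units; within the scatter). For compound 4 the estimated value is 24000 nM, with an expected range from 11000 nM to 50000 nM.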

Compound 4, half-maximal inhibitory concentration: 6370 nM
Compound 4: the middle estimate sits 3.8-fold (0.58 log units) above what was measured; measured number below the stated range.
By their numbers in this assay, from the lowest: compounds 4, 1, 2 and 3 (each within the scatter of the next, the first and the last beyond it).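

On the 2-(hydroxycarbamoyl)ethyl chain in this assay, nitro in place of hydrogen on the aromatic carbon gives a 2.5-fold lower number from compound 3 to compound 4 (0.41 log units; beyond the scatter), so the effect of a group at this place cannot be read apart from the chain. The nitro exchange does not carry over from one chain to the other: the same change on two cores in this assay, a 1.9-fold higher number (0.29 log units; within the scatter) from compound 1 to compound 2 and a 2.5-fold lower number (0.41 log units; beyond the scatter) from compound 3 to compound 4, 4.9-fold (0.69 log units) apart, beyond the scatter of two such steps. Seen from the chain, 2-(hydroxycarbamoyl)ethyl in place of 2-(hydroxycarbamoyl)ethenyl gives a 2.0-fold lower number from compound 2 to compound 4 (0.30 log units; within the scatter), so the clear step that this change produced without the nitro group is not reproduced with it: the same change on two cores in this assay, a 2.5-fold higher number (0.40 log units; beyond the scatter) from compound 1 to compound 3 and a 2.0-fold lower number (0.30 log units; within the scatter) from compound 2 to compound 4, 4.9-fold (0.69 log units) apart, beyond the scatter of two such steps.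

Whether this dependence on the chain also holds for other groups at the same place, such as an amine or a carboxylic acid, stays open, as does whether a longer chain would follow either of the two chains shown. The pattern rests on these four compounds alone, and their numbers do not tell why the nitro exchange differs between the two chains.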